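The source may report more compounds than this note shows. Statements on the series, on what has been measured and on what is new or still open speak of the compounds shown alone.

Measured so far:
- compound 1 `C=C(c1cc(OC)c(OC)c(OC)c1)c1ccc(OC)cc1NC(=O)CN(C)C`: 240 nM
- compound 2 `C=C(c1cc(OC)c(OC)c(OC)c1)c1ccc(OC)c(O)c1NC(=O)COC`: 450 nM
- compound 3 `C=C(c1cc(OC)c(OC)c(OC)c1)c1ccc(OC)c(O)c1NC(=O)COCC`: 1230 nM

All three values come from a functional assay on A2780 cells (Homo sapiens) for antiproliferative activity, read by MTT assay, with a stated time of 48 h; a higher number here means a weaker inhibitor, a lower number a stronger inhibitor. Among them, compound 3 has the highest number, at 1230 nM, so it is the weakest inhibitor of the set. Its values lie beyond the scatter from those of both other compounds.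

The next compound is compound 4 `C=C(c1cc(OC)c(OC)c(OC)c1)c1ccc(OC)c(O)c1NC(=O)CN(C)C`, which has dimethylamino in place of ethoxy on a saturated chain carbon bound to a carbonyl carbon.

Among the compounds with values here, the only measured step within this chain is a 2.7-fold higher number from compound 2 to compound 3 (0.44 log units; beyond the scatter). It is modest, and it is a methyl for hydrogen change on the ether chain, so it bears on the new step only indirectly. Within the data shown here, it shows that the number responds to a small edit here, but no measured step swaps ethoxy for dimethylamino.

Among the measured compounds shown here, the closest guide is compound 1, the only measured compound with dimethylamino in this place, at 240 nM. Its core differs from that of compound 3, so this comparison remains loose.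

On that basis, a modest move towards a lower number is expected. The expected step is a 3.5-fold lower number from compound 3 to compound 4 (0.55 log units; beyond the scatter) in this assay.

For compound 4 the estimated value is 350 nM, with an expected range of 120 nM to 1000 nM.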

Compound 4, half-maximal inhibitory concentration: 90 nM
Compound 4: the middle estimate sits 3.9-fold (0.59 log units) above what was measured, and the stated range ends above it.
By their numbers in this assay, from the lowest: compound 4; then compounds 1 and 2 (each within the scatter of the next); then compound 3.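

In this assay, the chain end on a saturated chain carbon bound to a carbonyl carbon can now be read directly on one shared core: dimethylamino in place of ethoxy gives a 14-fold lower number from compound 3 to compound 4 (1.14 log units; beyond the scatter), and dimethylamino in place of methoxy gives a 5.0-fold lower number from compound 2 to compound 4 (0.70 log units; beyond the scatter). With dimethylamino held constant, hydroxy in place of hydrogen on an aromatic carbon gives a 2.7-fold lower number from compound 1 to compound 4 (0.43 log units; beyond the scatter), so this edit also moves the number beyond the scatter, and compound 4 is the strongest inhibitor of the four. Nothing available explains the size of these steps.

The compounds shown leave open whether hydroxy in place of hydrogen on an aromatic carbon would give a similar step with methoxy or ethoxy at the chain end, since only the dimethylamino pair allows this reading. They also leave open how far the result extends to other amines, such as a primary amine, diethylamino or pyrrolidine, and whether a longer chain between the carbonyl and the amine would keep it.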